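The source may hold more compounds than are shown below. What is called first, only, known or untested is meant among the compounds shown, and "the series" means these compounds.

Measured compounds in an assay on isolated protein for inhibition of P-selectin glycoprotein ligand 1 (Homo sapiens), read by surface plasmon resonance, tested at 250 uM; on this read-out lower numbers stand for less inhibition and higher numbers for more inhibition at the one concentration tested (going by the name of the read-out):
- compound 1 `COc1ccc(C2(c3nc4c(C(F)(F)F)cccc4c(C(=O)O)c3O)CC2)cc1`: 26%
- compound 2 `Cc1cc(C)c2nc(C3(c4ccc(Cl)cc4)CC3)c(O)c(C(=O)O)c2c1`: 47%
- compound 3 `CC(C)C(c1ccc(Cl)cc1)c1nc2c(C(F)(F)F)cccc2c(C(=O)O)c1O`: a limit of the assay, <= 10%

Compound 1 stands lowest of the two numbers shown; compound 2 reads higher by a margin beyond the usual scatter. Compound 3 gives no number in this assay, only the limit (the limit of <= 10% in this assay, at which 1 of the 3 values shown sits).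

Compound 4 `O=C(O)c1c(O)c(C2(c3cccs3)CC2)nc2c(C(F)(F)F)cccc12` has not yet been measured. It differs from compound 1 in one place: thiophen-2-yl in place of 4-methoxyphenyl on a saturated ring carbon. Within the data shown here, no pair of measured compounds shows a step of this kind, so the size of the step from compound 1 to compound 4 in this assay is open. Both groups are a single aromatic ring carrying one hydrogen-bond acceptor and no donor, and the change is expected to produce no step beyond the scatter, with the next reading for compound 4 falling near that of compound 1. The estimate for compound 4 is 22%, between 8% and 40%, the expected step being a number 4 percentage points lower from compound 1 to compound 4 (within the scatter).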

Compound 4, a percentage reported as inhibition, at one concentration (the size of the read-out at that concentration, not a potency): 15%
Beside the measured number, compound 4's estimate is 7 percentage points above it; the range from low to high includes it.
By their numbers in this assay, from the lowest: compound 4; then compound 1; then compound 2. At a limit, below all of these: compound 3.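

Among these compounds, on a saturated ring carbon of the three-membered ring, the aromatic group is not interchangeable in this assay: thiophen-2-yl in place of 4-methoxyphenyl gives a number 11 percentage points lower from compound 1 to compound 4 (beyond the scatter), the first single-place change that can be read. This position therefore responds to the identity of the group even though the two groups have equal counts of hydrogen-bond donors and acceptors, but one pair cannot separate the change in ring size, the loss of the methoxy group and the entry of sulfur. Compound 3 holds a limit, not a number: the limit of <= 10% in this assay, at which 1 of the 4 values shown sits.

Still open, as far as these compounds go, is whether an unsubstituted phenyl or a 4-aminophenyl at this place would read with compound 1 or with compound 4. Compound 2 and compound 3 differ from compound 1 in more than one place, so they give no further reading of this position.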